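The source may hold more compounds than are shown below. What is called first, only, known or untested is meant among the compounds shown, and "the series" means these compounds.

Compound 1, `Cc1ccccc1OS(=O)(=O)c1cccc(NC(=O)NCCCCl)c1`, in a functional assay on MCF7 cells (Homo sapiens) for cytotoxicity, read by sulforhodamine B assay, with a stated time of 48 h; a higher number here means a weaker inhibitor, a lower number a stronger inhibitor: 27000 nM
Compound 2, `CCc1ccccc1OS(=O)(=O)c1cccc(NC(=O)NCCCCl)c1`, in this assay: 25000 nM
Compound 3, `Cc1ccccc1OS(=O)(=O)c1ccc(NC(=O)NCCCCl)cc1`, in this assay: 27000 nM

Compound 3 stands at the same number as compound 1 at the digits given, and its distance from compound 2 is also inside the scatter, so the three measured compounds are, for practical purposes, indistinguishable in this assay.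

Compound 4, `CCc1ccccc1OS(=O)(=O)c1ccc(NC(=O)NCCCCl)cc1`, is not yet measured. It differs from compound 3 by methyl in place of hydrogen on a saturated chain carbon bound to an aromatic carbon; seen one bond further out, this reads methyl to ethyl, or 2-methylphenyl to 2-ethylphenyl. The same change has already been made once on the shared core, between compound 1 and compound 2, and there it gave a 1.1-fold lower number from compound 1 to compound 2 (0.03 log units; within the scatter). On that single precedent, no step beyond the scatter is expected in this assay for compound 4, though one pair is a thin base.

Compound 4 is therefore estimated at 25000 nM, within 15000 nM to 42000 nM, which corresponds to an expected step of a 1.1-fold lower number from compound 3 to compound 4 (0.03 log units; within the scatter).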

Compound 4, half-maximal inhibitory concentration: 15000 nM
Compound 4: middle estimate off by 1.7-fold (0.22 log units), on the high side; measured number inside the range.
By their numbers in this assay, from the lowest: compounds 4, 2, 1 and 3 (each within the scatter of the next).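

Changing 2-methylphenyl to 2-ethylphenyl on this second core gives a 1.8-fold lower number from compound 3 to compound 4 (0.26 log units; within the scatter) in this assay. The change can now be read on two cores rather than one, and the two readings agree: the same change on two cores in this assay, a 1.1-fold lower number (0.03 log units; within the scatter) from compound 1 to compound 2 and a 1.8-fold lower number (0.26 log units; within the scatter) from compound 3 to compound 4, 1.7-fold (0.22 log units) apart, within the scatter of two such steps Across these two pairs, then, adding a methyl on the saturated chain carbon bound to an aromatic carbon does not move the number beyond the scatter, and neither pair goes against this.

The compounds shown carry only methyl and ethyl at this place, so it remains open whether a longer chain, an amine or a carboxylic acid there would give a step beyond the scatter. With every step here inside the scatter, they also do not show which part of these molecules matters for the cytotoxicity.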